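From Furan to Hydroxyphenyl on the Shared Amide Core

This account rests on a few compounds, and the source may have more. Where it says the series, first, only, none or still open, it means among the compounds named here.

Of the compounds shown here, two that share one core have been tested in a functional assay on the whole organism (strain CF-1) with Mus musculus as the target, in the writhing test, with a stated time of 15 min (on this read-out lower numbers stand for an effect already at smaller amounts and higher numbers for an effect only at larger amounts of compound), so far. Compound 1 `O=C(/N=C1\NC2(CCCCO2)CCS1)c1ccc(Cl)cc1` carries a 4-chlorophenyl group on the carbonyl carbon and gives 1.1 mg/kg. Among the compounds with values here, compound 2 `O=C(/N=C1\NC2(CCCCO2)CCS1)c1ccco1` has a furan-2-yl group at the same place and gives 42 mg/kg, which is the higher of the two numbers; the only measured step, a 38-fold higher number from compound 1 to compound 2 (1.58 log units; beyond the scatter), is a large one beyond the usual scatter.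

Compound 3 `O=C(/N=C1\NC2(CCCCO2)CCS1)c1ccccc1O` is the next compound in this series. It differs from compound 2 by 2-hydroxyphenyl in place of furan-2-yl on a carbonyl carbon. Within the data shown here, no measured step covers this exact change. Among the measured compounds shown here, the one step that bears on it is the step from compound 1 to compound 2, where leaving a six-membered carbon-only ring for the five-membered furan ring raised the number greatly. Since compound 3 returns to a six-membered carbon-only ring, though with a hydroxyl instead of a chlorine, a lower number than that of compound 2 is expected, and the estimated step of a 7.0-fold lower number from compound 2 to compound 3 (0.85 log units; beyond the scatter) is set between the two measured values. Compound 3 is therefore estimated at 6 mg/kg, within a range from 1.5 mg/kg to 25 mg/kg.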

Compound 3, dose for half-maximal effect: > 200 mg/kg
Compound 3 gave a limit, no number (the forecaster's own chance of this, stated with the estimate: 5%); middle value at least 33-fold (1.52 log units) away from the limit.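

In this assay compound 3 reaches only a limit and not a number: the limit of > 200 mg/kg in this assay, at which 1 of the 3 values shown sits. Even so, the steps can be read in one direction: the change from the furan ring to 2-hydroxyphenyl gives an at least 4.7-fold higher number from compound 2 to compound 3 (0.67 log units; beyond the scatter), and the change from 4-chlorophenyl to 2-hydroxyphenyl gives an at least 180-fold higher number from compound 1 to compound 3 (2.25 log units; beyond the scatter). The earlier pair left open whether a six-membered carbon-only ring on the carbonyl carbon might be enough for a low number, but compound 1 and compound 3 both carry such a ring and still lie far apart, so what the ring bears matters at least as much as the ring itself.

The compounds shown cannot separate the swap of chlorine for hydroxyl from the shift in where the group sits on the ring, as 4-chlorophenyl and 2-hydroxyphenyl differ in both respects. A 4-hydroxyphenyl or a 2-chlorophenyl group would pull these two changes apart, and an unsubstituted phenyl group would show what the ring gives on its own.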